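Nitro in Place of Carboxy on the Anilino Group

The source may hold more compounds than are shown below. What is called first, only, known or untested is meant among the compounds shown, and "the series" means these compounds.

Of the compounds shown here, three sharing one core have been tested in a functional assay on the whole organism for inhibition, with Rattus norvegicus as the target, read by paw edema, with stated times of 1 h and 6 h, at a dose of 0.03 mg/kg by the oral route; on this read-out higher numbers stand for more inhibition at the one dose given (going by the name of the read-out) and lower numbers for less inhibition. Compound 1 `CC1=NN(C(=O)c2cc3ccccc3oc2=O)C(=O)C1CNc1ccccn1` gives 50.3%. Compound 2 `CC1=NN(C(=O)c2cc3ccccc3oc2=O)C(=O)C1CNc1cccc(S(N)(=O)=O)c1` gives 79.9%, and compound 3 `CC1=NN(C(=O)c2cc3ccccc3oc2=O)C(=O)C1CNc1ccc(C(=O)O)cc1` gives 72.6%. Compound 3 thus stands second of the three numbers: the step of a number 22.3 percentage points higher from compound 1 to compound 3 (beyond the scatter) lies beyond the scatter, whereas the step of a number 7.3 percentage points lower from compound 2 to compound 3 (within the scatter) lies within it, so compounds 2 and 3 cannot be told apart on these numbers.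

Compound 4 `CC1=NN(C(=O)c2cc3ccccc3oc2=O)C(=O)C1CNc1ccc([N+](=O)[O-])cc1` has not yet been measured. It differs from compound 3 in one place: nitro in place of carboxy on an aromatic carbon. Two measured steps show that exchanging the group on the amine nitrogen can move the read-out, namely a number 29.6 percentage points higher from compound 1 to compound 2 (beyond the scatter) and a number 22.3 percentage points higher from compound 1 to compound 3 (beyond the scatter); the third, a number 7.3 percentage points lower from compound 2 to compound 3 (within the scatter), shows that two different groups on a six-membered aromatic ring of carbon only gave numbers within the scatter of each other. Among the measured compounds shown here, no measured compound carries a nitro group, so the present change has no direct precedent here. Because of a number 7.3 percentage points lower from compound 2 to compound 3 (within the scatter), the expected step of a number 4.6 percentage points lower from compound 3 to compound 4 (within the scatter) is small, with no clear direction beyond the scatter. Compound 4 is therefore estimated to give 68%, within a range from 48% to 85%.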

Compound 4, a percentage reported as inhibition, in the whole organism at one dose (the size of the read-out at that dose, not a potency): 72%
Beside the measured number, compound 4's estimate is 4 percentage points below it; the measured number falls inside the stated range.
By their numbers in this assay, from the lowest: compound 1; then compounds 4, 3 and 2 (each within the scatter of the next).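

In this assay, nitro in place of carboxy gives a number 0.6 percentage points lower from compound 3 to compound 4 (within the scatter) even though the entering group has no hydrogen-bond donor and the leaving group has one, so for this pair the read-out does not depend on that donor at this place, para to a large group. The 4-nitrophenyl compound also gives a number 7.9 percentage points lower from compound 2 to compound 4 (within the scatter) and a number 21.7 percentage points higher from compound 1 to compound 4 (beyond the scatter) so that compounds 2, 3 and 4, which all carry a six-membered aromatic ring of carbon only, lie within the scatter of one another, while compound 1 with its pyridin-2-yl group gives a lower number than each of them. No measured data here offer a reason for either result.

As far as these compounds go, whether an amino group, a methyl group or a chlorine atom on the same aromatic carbon would also stay within the scatter of compound 3 remains open, as does the effect of having no group at all there. Since each number comes from a single dose, these compounds could still separate at a lower dose, which would show differences that the present read-out cannot.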